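Methylsulfonyl for Ethyl at Two Places on One Core

The source may report more compounds than this note shows. Statements on the series, on what has been measured and on what is new or still open speak of the compounds shown alone.

Compound 1 `CCOC1=CC(=O)c2ccccc2C1=O` is the starting point. In a functional assay on KB cells (Homo sapiens) for cytotoxicity (a lower number here means a stronger inhibitor, a higher number a weaker inhibitor), compound 1 gives 16900 nM. Compound 2 `CS(=O)(=O)OC1=CC(=O)c2ccccc2C1=O` differs from it by methylsulfonyl in place of ethyl on an oxygen on an unsaturated carbon; in this assay compound 2 gives 7180 nM, and the change made a 2.4-fold lower number from compound 1 to compound 2 (0.37 log units; beyond the scatter). Compound 3 `CCOc1ccc2c(c1)C(=O)C=CC2=O` has the same atoms as compound 1 joined differently; the difference between the two cores is not broken down here. In this assay compound 3 gives 21400 nM, a number within the scatter of that of compound 1, while its gap to compound 2 lies beyond the scatter.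

Compound 4 `CS(=O)(=O)Oc1ccc2c(c1)C(=O)C=CC2=O` has not been measured. It differs from compound 3 by methylsulfonyl in place of ethyl on an oxygen on an aromatic ring. Going by the values given here, this is the same kind of change as the one from compound 1 to compound 2, but not the same: in compound 1 the oxygen is on an unsaturated carbon whose other neighbours are a double-bonded ring carbon, whereas in compound 3 it is on an aromatic ring whose other neighbours are aromatic carbon. The change has been seen only once among these compounds, so its effect at the new place is not known. Among the compounds with values here, a step of similar direction and size, a 2.1-fold lower number from compound 3 to compound 4 (0.33 log units; beyond the scatter), is nevertheless expected, because the one prior instance gave a 2.4-fold lower number from compound 1 to compound 2 (0.37 log units; beyond the scatter). On that basis compound 4 is estimated at 10000 nM in this assay, with a range from 4000 nM to 25000 nM that allows for the difference in place.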

Compound 4, half-maximal inhibitory concentration: 11600 nM
Beside the measured number, compound 4's estimate is 1.2-fold (0.06 log units) below it; low and high end bracket the measured number.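

In this assay, putting methylsulfonyl in place of ethyl on an oxygen on an aromatic ring gives a 1.8-fold lower number from compound 3 to compound 4 (0.27 log units; within the scatter), a step that, taken alone, cannot be told apart from repeat measurement, whereas the step on the core of compound 1 stood clear of it. Set side by side, the two steps show no difference between the cores, so the result is compatible with this change carrying over from one core to the other: the same change on two cores in this assay, a 2.4-fold lower number (0.37 log units; beyond the scatter) from compound 1 to compound 2 and a 1.8-fold lower number (0.27 log units; within the scatter) from compound 3 to compound 4, 1.3-fold (0.11 log units) apart, within the scatter of two such steps. This does not establish that the step on the core of compound 3 is real in its own right, and two pairs of compounds give no rule for any further core or replacement.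

The compounds shown leave open how other groups on the same oxygen would read, such as a longer chain like propyl, an acetyl group or a plain hydroxyl, and whether an amine at that place would fit the same picture. They also leave open whether the step would keep its size on a third core, or in any assay other than this assay.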